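The source may hold more compounds than are shown below. What is called first, only, known or untested is meant among the compounds shown, and "the series" means these compounds.

Measured so far:
- compound 1 `Nc1cccc(-c2cccc(NC(=O)C(Cl)Cl)c2)c1`: 50000 nM
- compound 2 `Cc1ccc(-c2cccc(NC(=O)C(Cl)Cl)c2)cc1`: 8300 nM

In a functional assay on A549 cells (Homo sapiens) for cytotoxicity, read by MTT assay, with a stated time of 68 h (on this read-out higher numbers stand for weaker inhibition and lower numbers for stronger inhibition), compound 2 gives 8300 nM, the lower of the two numbers and so the stronger inhibition. Compound 1 gives 50000 nM, and the gap between the two values lies beyond the scatter.

The next compound to be tested is compound 3 `O=C(Nc1cccc(-c2ccccc2)c1)C(Cl)Cl`. Its difference from compound 2 is hydrogen in place of methyl on an aromatic carbon, which places hydrogen in place of methyl on an aromatic carbon, para to a large group. Among the measured compounds shown here, no pair of measured compounds isolates this change, so the series offers no direct precedent for its size. Only a small shift in this assay is expected, towards a higher number and weaker inhibition, and it may not exceed the scatter. The estimated change is a 1.7-fold higher number from compound 2 to compound 3 (0.23 log units; within the scatter). For compound 3 the expected value is 14000 nM, with an estimated range of 6000 nM to 35000 nM.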

Compound 3, half-maximal inhibitory concentration: 8900 nM
Compound 3: middle estimate off by 1.6-fold (0.20 log units), on the high side; the measured number falls inside the stated range.
By their numbers in this assay, from the lowest: compounds 2 and 3 (each within the scatter of the next); then compound 1.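

In this assay, hydrogen in place of methyl on an aromatic carbon, para to a large group, gives a 1.1-fold higher number from compound 2 to compound 3 (0.03 log units; within the scatter), so the two compounds cannot be told apart and the methyl at this position has no measurable effect on the read-out. Hydrogen in place of amino on an aromatic carbon gives a 5.6-fold lower number from compound 1 to compound 3 (0.75 log units; beyond the scatter); this is the first comparison in the series that isolates the amino group, and it sets compound 1 apart from compound 3 by that one group, with the amino compound giving the weaker inhibition of the pair. No supporting measurement bears on the size of either step.

From the compounds shown here alone, at the position para to a large group, only methyl and hydrogen can be compared, so it remains open whether a larger or different group, such as a methoxy group, a carboxylic acid or a longer alkyl chain, would move the number beyond the scatter. Going by these compounds, it also remains open whether an amino group at that same position would match the step seen for compound 1, since compound 1 and compound 2 differ in more than one place.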